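Amide variation in the sulfonamide-piperidine series

This account rests on a few compounds, and the source may have more. Where it says the series, first, only, none or still open, it means among the compounds named here.

Compound 1, `O=C(c1ccc(C(F)(F)F)cc1)N1CCC(NS(=O)(=O)c2cc(S(=O)(=O)c3ccccc3)ccc2C(F)(F)F)CC1`, in an assay on isolated protein for displacement of a labelled ligand from secreted frizzled-related protein 1 (Homo sapiens), read by fluorescence polarization, with a stated time of 30 min; a higher number here means a weaker inhibitor, a lower number a stronger inhibitor: 400 nM
Compound 2, `O=C(c1cccnc1)N1CCC(NS(=O)(=O)c2cc(S(=O)(=O)c3ccccc3)ccc2C(F)(F)F)CC1`, in this assay: 80 nM
Compound 3, `O=C(c1ccc(Cl)nc1)N1CCC(NS(=O)(=O)c2cc(S(=O)(=O)c3ccccc3)ccc2C(F)(F)F)CC1`, in this assay: 110 nM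

Compound 3 holds the second highest of the three numbers. The nearest is compound 2: a 1.4-fold higher number from compound 2 to compound 3 (0.14 log units; within the scatter). The furthest is compound 1: a 3.6-fold lower number from compound 1 to compound 3 (0.56 log units; beyond the scatter). The related exchange gives a 5.0-fold lower number from compound 1 to compound 2 (0.70 log units; beyond the scatter), so both changes at the carbonyl carbon of compound 1 moved the number modestly, and in the same direction.

Compound 4, `CC(C)(C)OC(=O)N1CC[C@H](C(=O)N2CCC(NS(=O)(=O)c3cc(S(=O)(=O)c4ccccc4)ccc3C(F)(F)F)CC2)C1`, differs from compound 3 as follows: 1-(tert-butoxycarbonyl)pyrrolidin-3-yl in place of 6-chloropyridin-3-yl on a carbonyl carbon. Among the measured compounds shown here, none of the measured steps bears closely on this change. For the measured compounds named here, both measured steps swap one aromatic group for another on the same carbonyl carbon; a saturated ring carrying a carbamate has no counterpart among the measured compounds. They only set a scale: modest steps at this position. No direction can be read from them.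

Compound 4 is therefore expected near 200 nM, in a range from 60 nM to 700 nM, which means an expected step of a 1.8-fold higher number from compound 3 to compound 4 (0.26 log units; within the scatter).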

Compound 4, half-maximal inhibitory concentration: 70 nM
For compound 4 the middle estimate is 2.9-fold (0.46 log units) above the measured one; measured number inside the range.
By their numbers in this assay, from the lowest: compounds 4, 2 and 3 (each within the scatter of the next); then compound 1.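

In this assay the group on the carbonyl carbon need not be aromatic: the saturated 1-(tert-butoxycarbonyl)pyrrolidin-3-yl cannot be told apart from either pyridine group (a 1.6-fold lower number from compound 3 to compound 4 (0.20 log units; within the scatter); a 1.1-fold lower number from compound 2 to compound 4 (0.06 log units; within the scatter)), despite its larger heavy-atom count. Among the four compounds, only compound 1 stands apart, and the step to the carbamate (a 5.7-fold lower number from compound 1 to compound 4 (0.76 log units; beyond the scatter)) has the same direction and modest size as the two aromatic exchanges from compound 1. Nothing available explains these steps.

The compounds shown do not separate the tert-butoxycarbonyl group from the pyrrolidine ring, so a free ring amine or an acetyl group on that nitrogen would be informative. From the compounds shown here alone, the opposite configuration at the stereocentre and an unsubstituted phenyl on the carbonyl carbon also remain open.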